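Naphthalen-2-yl Amide on a Bis-Indole Core: Expected Cytotoxicity

The compounds below may be only part of what the source reports. "The series", "measured", "known", "first", "only" and "open" are said of these compounds alone.

The set rests on a shared core carrying an amide side chain; only the aryl group on the carbonyl carbon varies. Compound 1 `COc1ccc(C(=O)NC[C@H]2c3[nH]c4ccccc4c3C[C@H]3[C@H]4c5[nH]c6ccccc6c5C[C@@H]([C@H](C#N)N23)N4C)cc1` gives 320 nM in a functional assay on BGC-823 cells (Homo sapiens) for cytotoxicity, read by MTT assay, with a stated time of 72 h (on this read-out higher numbers stand for weaker inhibition and lower numbers for stronger inhibition), and compound 2 `CN1[C@@H]2c3[nH]c4ccccc4c3C[C@H]1[C@H](C#N)N1[C@@H](CNC(=O)c3ccc(F)cc3)c3[nH]c4ccccc4c3C[C@@H]21` gives 310 nM, the two showing a 1.0-fold lower number from compound 1 to compound 2 (0.01 log units; within the scatter). Compound 3 `CN1[C@@H]2c3[nH]c4ccccc4c3C[C@H]1[C@H](C#N)N1[C@@H](CNC(=O)c3cccc4c3CCCC4)c3[nH]c4ccccc4c3C[C@@H]21` gives 3540 nM and so stands highest of the three numbers, meaning the weakest inhibition shown. Two steps reach it: an 11-fold higher number from compound 1 to compound 3 (1.04 log units; beyond the scatter) and an 11-fold higher number from compound 2 to compound 3 (1.06 log units; beyond the scatter), both large and in the same direction.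

Compound 4 `CN1[C@@H]2c3[nH]c4ccccc4c3C[C@H]1[C@H](C#N)N1[C@@H](CNC(=O)c3ccc4ccccc4c3)c3[nH]c4ccccc4c3C[C@@H]21` differs from compound 3 in one place: naphthalen-2-yl in place of 1,2,3,4-tetrahydronaphthalen-5-yl on a carbonyl carbon. For the measured compounds named here, no measured step contains this exact change, so the reading leans on the two steps into compound 3. Both show that swapping the aryl group on the carbonyl carbon can move the number well beyond the scatter, and that the tetrahydronaphthalen-5-yl group sits at the weak end. Removing that group in favour of a fully aromatic naphthalen-2-yl is therefore expected to bring the number back toward compounds 1 and 2, though not necessarily all the way. Compound 4 is estimated at 900 nM, within 300 nM to 2700 nM, a step of a 3.9-fold lower number from compound 3 to compound 4 (0.59 log units; beyond the scatter).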

Compound 4, half-maximal inhibitory concentration: 1110 nM
Beside the measured number, compound 4's estimate is 1.2-fold (0.09 log units) below it, and the stated range covers the measured number.
By their numbers in this assay, from the lowest: compounds 2 and 1 (each within the scatter of the next); then compound 4; then compound 3.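

In this assay, the step of a 3.2-fold lower number from compound 3 to compound 4 (0.50 log units; beyond the scatter) shows that this position on the carbonyl carbon responds beyond the scatter even when the entering and leaving groups have the same heavy-atom count and the same counts of hydrogen-bond donors and acceptors, and so differ only in how those carbons are arranged. The recovery is only partial: the steps of a 3.6-fold higher number from compound 2 to compound 4 (0.55 log units; beyond the scatter) and a 3.5-fold higher number from compound 1 to compound 4 (0.54 log units; beyond the scatter) leave naphthalen-2-yl on the weaker side of both the 4-fluorophenyl and the 4-methoxyphenyl groups, so in these four compounds the two fused-ring groups both give higher numbers than the two single-ring groups. Nothing measured on these compounds bears on why the number moves at this position.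

The change from compound 3 to compound 4 alters both ring saturation and the point of attachment, so the compounds shown cannot separate the two; a naphthalen-1-yl group on the same carbonyl carbon would begin to do so. They also leave open how this position responds to a single ring carrying an amine or a carboxylic acid, or to a pyridin-3-yl ring.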